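The source may report more compounds than this note shows. Statements on the series, on what has been measured and on what is new or still open speak of the compounds shown alone.

Three related compounds have been measured in a physicochemical assay for lipophilicity; on this read-out higher numbers stand for higher lipophilicity and lower numbers for lower lipophilicity. Compound 1 `COc1ccc(/C=C2\CCC/C(=C\c3ccc([N+](=O)[O-])cc3)C2=O)cc1` gives 5.08. Compound 2 `O=C1/C(=C/c2ccc(F)cc2)CCC/C1=C\c1cccc([N+](=O)[O-])c1` gives 5.06, and compound 3 `COc1ccc(/C=C2\CCC/C(=C\c3ccccc3[N+](=O)[O-])C2=O)cc1` gives 4.86. Compound 1 shows the highest of the three numbers, but both other numbers lie within the usual scatter of it, so the three cannot be separated with confidence on this assay.

A fourth compound, compound 4 `CN(C)c1ccc(/C=C2\CCC/C(=C\c3ccc([N+](=O)[O-])cc3)C2=O)cc1`, has not yet been measured. It differs from compound 1 in one place: dimethylamino in place of methoxy on an aromatic carbon. For the measured compounds named here, no pair of measured compounds in this set shows the same exchange, so the size of its effect cannot be read off from a measured step. Judged from the structural change alone, compound 4 is expected to come out only slightly higher than compound 1, a step of a number 0.17 log units higher from compound 1 to compound 4 (within the scatter), which would stay within the scatter. Compound 4 is therefore estimated at 5.25, with a range from 4.95 to 5.55.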

Compound 4, partition coefficient: 5.08
The estimate for compound 4 lay 0.17 log units above the measured number, and the stated range covers the measured number.
By their numbers in this assay, from the lowest: compounds 3, 2, 1 and 4 (each within the scatter of the next).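

Going from 4-methoxyphenyl to 4-(dimethylamino)phenyl, on an aromatic carbon para to a large group, this assay shows no change at the digits printed from compound 1 to compound 4 (within the scatter), with the rest of the molecule unchanged. For the compounds shown here, this is the first measured step in the set between compounds that differ in one place, and it shows that methoxy and dimethylamino cannot be told apart on this read-out at this position of the core of compound 1. Nothing at hand explains this outcome.

On these data alone, whether a quite different group at the same place, such as a carboxylic acid or a longer chain like butoxy, would give a step beyond the scatter remains open. So does whether dimethylamino in place of methoxy would give the same result on compound 3, which also carries methoxy.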